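Trading chloro for pentyl at the assay limit

The source may report more compounds than this note shows. Statements on the series, on what has been measured and on what is new or still open speak of the compounds shown alone.

In an ADME assay on J774 cells (Mus musculus) for cytotoxicity (on this read-out lower numbers stand for an effect already at smaller amounts and higher numbers for an effect only at larger amounts of compound), compound 1 `COC(=O)c1c[nH]c2cc(OCCOc3ccccc3)c(Cl)cc2c1=O` gives > 20000 nM, which is a limit of the assay and not a number. Compound 2 `CCCCc1ccc2[nH]cc(C(=O)OC)c(=O)c2c1` gives > 20000 nM, also a limit. That is the whole record so far: the limit of > 20000 nM in this assay, at which 2 of the 2 values shown sit. Compound 3 `CCCCCc1cc2c(=O)c(C(=O)OC)c[nH]c2cc1OCCOc1ccccc1` has not yet been measured. It differs from compound 1 in one place: pentyl in place of chloro on an aromatic carbon, with pentyl in place of chloro on an aromatic carbon. For the measured compounds named here, no two measured compounds differ in just one place, so the data offer no earlier step to borrow. The expectation therefore leans on compound 1, whose > 20000 nM is a limit. In this assay, no shift beyond the usual scatter is expected, and the estimated step is a number no higher from compound 1 to compound 3 (the limit leaves the size open). For compound 3 the expected value is 20000 nM, with an estimated range of 8000 nM to 40000 nM.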

Compound 3, half-maximal effective concentration: > 20000 nM
Compound 3: only a limit was reported (the forecaster's own chance of this, stated with the estimate: 70%); the middle value lies on the limit itself.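

Compound 1 and compound 3 both give a limit of the assay and not a number, so no step can be read for pentyl in place of chloro. The compounds shown leave open at what amount any of them would show an effect: the limit of > 20000 nM in this assay, at which 3 of the 3 values shown sit.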